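Four thiadiazole-thiazole amines in the electroshock model

This account rests on a few compounds, and the source may have more. Where it says the series, first, only, none or still open, it means among the compounds named here.

This account concerns three measured compounds and one that awaits measurement. Compound 1 `COc1ccccc1Nc1nnc(Nc2nc(-c3ccc(Cl)cc3)cs2)s1`, compound 2 `COc1ccc(Nc2nnc(Nc3nc(-c4ccc(Cl)cc4)cs3)s2)cc1` and compound 3 `COc1ccccc1Nc1nnc(Nc2nc(-c3ccc([N+](=O)[O-])cc3)cs2)s1` share a core and were all tested in a functional assay on the whole organism (strain albino) with Mus musculus as the target, in the maximal electroshock model, with a stated time of 4 h; a lower number here means that less compound is needed, a higher number that more compound is needed for the effect. In this assay compound 1 gives 300 mg/kg, compound 2 gives 300 mg/kg and compound 3 gives 300 mg/kg.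

Two single changes connect these three. From compound 1 to compound 2 the change is 4-methoxyphenyl in place of 2-methoxyphenyl on a nitrogen on an aromatic ring, and the step in this assay is no change at the digits printed from compound 1 to compound 2 (within the scatter). From compound 1 to compound 3 the change is nitro in place of chloro on an aromatic carbon, with a step of no change at the digits printed from compound 1 to compound 3 (within the scatter). Neither alteration moved the minimum effective dose at the digits recorded.

Compound 4 `COc1ccc(Nc2nnc(Nc3nc(-c4ccc([N+](=O)[O-])cc4)cs3)s2)cc1` has not yet been measured in this assay. It differs from compound 3 by 4-methoxyphenyl in place of 2-methoxyphenyl on a nitrogen on an aromatic ring, which is the same change already seen from compound 1 to compound 2, since the place is described in identical words; the two cores differ by the change described from compound 1 to compound 3. Because the earlier occurrence of this change gave no change at the digits printed from compound 1 to compound 2 (within the scatter), the author expects the step from compound 3 to compound 4 in this assay to be no change at the digits printed from compound 3 to compound 4 (within the scatter). Compound 4 is therefore estimated at 300 mg/kg in this assay. The estimate for compound 4 is expected to fall between 150 mg/kg and 600 mg/kg. Going by these compounds, whether this assay will report a number or only a limit for compound 4 remains open.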

Compound 4, minimum effective dose: 30 mg/kg
Compound 4: middle estimate off by 10-fold (1.00 log units), on the high side; measured number below the stated range.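

In this assay the change from 2-methoxyphenyl to 4-methoxyphenyl did not carry over from one core to the other, for the new step is a 10-fold lower number from compound 3 to compound 4 (1.00 log units; beyond the scatter), and the earlier step it was set against showed nothing of this size: the same change on two cores in this assay, no change at the digits printed (within the scatter) from compound 1 to compound 2 and a 10-fold lower number (1.00 log units; beyond the scatter) from compound 3 to compound 4, 10-fold (1.00 log units) apart, beyond the scatter of two such steps. Going by these compounds alone, the exchange of chloro for nitro behaves the same way, with a 10-fold lower number from compound 2 to compound 4 (1.00 log units; beyond the scatter) on the core bearing 4-methoxyphenyl, whereas on the core bearing 2-methoxyphenyl it gave no such step: the same change on two cores in this assay, no change at the digits printed (within the scatter) from compound 1 to compound 3 and a 10-fold lower number (1.00 log units; beyond the scatter) from compound 2 to compound 4, 10-fold (1.00 log units) apart, beyond the scatter of two such steps. Within these four compounds, then, neither change can be treated as a transferable increment, since the lower number appears only where 4-methoxyphenyl and nitro occur together, in compound 4; this does not show why the two changes depend on each other, and a single set of four compounds cannot show that the same would hold on any other core.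

The compounds shown leave open whether a nitrile or an amine in place of nitro would also give a lower number alongside 4-methoxyphenyl. They also leave open whether an ethoxy or a hydroxyl group in place of the methoxy of compound 4 would keep that number.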